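Swapping the propargylamine chain of compound 1 for a propargylpiperazine

The source may hold more compounds than are shown below. What is called first, only, known or untested is meant among the compounds shown, and "the series" means these compounds.

This account follows compound 1, `C#CCN(CCC)Cc1cn(-c2cc(NC(=S)NCC)ncn2)cn1`, into a single change at one position. In an assay on isolated protein for inhibition of Amine oxidase [flavin-containing] B (Homo sapiens), read by fluorescence and Amplex Red, with a stated time of 15 min (on this read-out lower numbers stand for stronger inhibition and higher numbers for weaker inhibition), compound 1 returns > 50000 nM, which is a limit of the assay and not a number. Compound 2, `C#CCN(Cc1ccccc1)Cc1cn(-c2cc(NC(=S)NCC)ncn2)cn1`, carries a phenyl in place of ethyl on a saturated chain carbon bound to an amine nitrogen. In this assay compound 2 likewise returns > 50000 nM, again a limit rather than a number. The step that the two limits leave unreadable from compound 1 to compound 2 therefore cannot be read, and compound 1 stands only at a limit, with no measured number to place it against. Both values shown sit at the limit of > 50000 nM in this assay, at which 2 of the 2 values shown sit.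

Compound 3, `C#CCN1CCN(Cc2cn(-c3cc(NC(=S)NCC)ncn3)cn2)CC1`, differs from compound 1 by a group of 9 heavy atoms (7 carbon, 2 nitrogen; one six-membered non-aromatic ring with 2 hetero atoms) in place of a group of 7 heavy atoms (6 carbon, 1 nitrogen; no ring), on a saturated chain carbon bound to an aromatic carbon. Among the measured compounds shown here, no measured step bears on this change; the one step available is unreadable. With both neighbours at the limit, compound 3 is expected to stay there too, and the step that the limit leaves unreadable from compound 1 to compound 3 is estimated as none beyond the scatter. For compound 3 the estimate is 70000 nM, within 20000 nM to 250000 nM, most likely reported again only as a limit.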

Compound 3, half-maximal inhibitory concentration: > 50000 nM
Compound 3: a limit, no number; the forecaster's own chance of this, stated with the estimate: 80%; the middle value lies beyond the limit too.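

In this assay compound 3 gives > 50000 nM, a limit of the assay and not a number. No step from compound 1 to compound 3 can be read, and the same holds for compound 2: the limit of > 50000 nM in this assay, at which 3 of the 3 values shown sit.

Compounds 1, 2 and 3 leave open whether the 4-propargylpiperazin-1-yl group changes inhibition at all, and how far any of the three lies beyond the limit.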